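This account rests on a few compounds, and the source may have more. Where it says the series, first, only, none or still open, it means among the compounds named here.

Measured so far, in a functional assay on A-431 cells (Homo sapiens) for cytotoxicity, read by MTT assay, with a stated time of 24 h; on this read-out lower numbers stand for stronger inhibition and higher numbers for weaker inhibition:

Compound 1 `COc1ccc(N(CC(=O)NCCC[Se]c2ccccc2)C(=O)CNC(=O)OC(C)(C)C)cc1` – in this assay compound 1 gives only the limit >= 100000 nM.
Compound 2 `COc1ccc(N(CC(=O)NCCCSc2ccccc2)C(=O)/C=C/c2ccccc2)cc1` – in this assay compound 2 gives only the limit >= 100000 nM.
Compound 3 `COc1ccc(N(CC(=O)NCCC[Se]c2ccccc2)C(=O)C#Cc2ccccc2)cc1` – in this assay compound 3 gives only the limit >= 100000 nM.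

Compound 3 therefore stands at the limit of this assay, not at a number, and the same holds for both other compounds (the limit of >= 100000 nM in this assay, at which 3 of the 3 values shown sit). Among the compounds with values here, the one measured step that reaches compound 3, from compound 1 to compound 3 a step that the two limits leave unreadable from compound 1 to compound 3, is unreadable because both ends are limits.

The unmeasured compound 4 `COc1ccc(N(CC(=O)NCCCSc2ccccc2)C(=O)C#Cc2ccccc2)cc1` differs from compound 3 by a group of 7 heavy atoms (6 carbon, 1 sulfur; one six-membered aromatic ring of carbon only) in place of a group of 7 heavy atoms (6 carbon, 1 selenium; one six-membered aromatic ring of carbon only), on a saturated chain carbon, three bonds along the chain from an amide-type nitrogen. Within the data shown here, no measured step addresses this exchange directly; compound 2 carries the same phenylsulfanyl group with a different acyl group and also sits at the limit. Among the measured compounds shown here, no step readable here gives any size, so no change beyond the scatter is expected from compound 3 to compound 4 a number no higher from compound 3 to compound 4 (the limit leaves the size open). Compound 4 is accordingly expected to remain at the limit, estimated as 100000 nM within 50000 nM to 300000 nM.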

Compound 4, half-maximal inhibitory concentration: >= 100000 nM
Compound 4: a limit, no number (the forecaster's own chance of this, stated with the estimate: 85%); the middle value lies on the limit itself.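

The result for compound 4 is again a limit, so the steps to it from compound 2 and compound 3 cannot be read, and the series offers no number: the limit of >= 100000 nM in this assay, at which 4 of the 4 values shown sit. The compounds shown leave open whether exchanging selenium for sulfur, or changing the acyl group, alters the read-out in this assay.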